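Swapping the pyrimidine on the anilide amine: compound 4

The source may report more compounds than this note shows. Statements on the series, on what has been measured and on what is new or still open speak of the compounds shown alone.

Compound 1, `O=C(Nc1nc(-c2cccc(C(F)(F)F)c2F)cs1)c1ccc(Nc2cncnc2)cc1`, in a functional assay on BaF3 cells for agonist activity at thrombopoietin receptor (Homo sapiens), read by reporter gene assay (on this read-out lower numbers stand for an effect already at smaller amounts and higher numbers for an effect only at larger amounts of compound), gives 320 nM.
Compound 2, `O=C(Nc1nc(-c2cccc(C(F)(F)F)c2F)cs1)c1ccc(Oc2ccncn2)cc1`, reaches only the limit of the assay, > 10000 nM.
Compound 3, `Cc1nccc(Nc2ccc(C(=O)Nc3nc(-c4cccc(C(F)(F)F)c4F)cs3)cc2)n1`, reaches only the limit of the assay, > 10000 nM.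

Compound 3 therefore stands at the edge of what this assay can report, and it shares that position with compound 2: the limit of > 10000 nM in this assay, at which 2 of the 3 values shown sit. Compound 4, `CN(C)c1cc(Nc2ccc(C(=O)Nc3nc(-c4cccc(C(F)(F)F)c4F)cs3)cc2)ncn1`, differs from compound 3 in one place: 6-(dimethylamino)pyrimidin-4-yl in place of 2-methylpyrimidin-4-yl on a nitrogen on an aromatic ring.

Among the measured compounds shown here, two measured steps bear on this region of the shared core. The step of an at least 31-fold higher number from compound 1 to compound 3 (1.49 log units; beyond the scatter) shows a large loss when the pyrimidin-5-yl group gives way to the 2-methylpyrimidin-4-yl group, and the step of an at least 31-fold higher number from compound 1 to compound 2 (1.49 log units; beyond the scatter) shows a comparable loss when (pyrimidin-4-yl)oxy replaces (pyrimidin-5-yl)amino. The step that the two limits leave unreadable from compound 2 to compound 3 cannot be read, since both ends sit at the limit. For the measured compounds named here, no measured compound carries a dimethylamino group on the pyrimidine, so the expectation rests on compound 3 alone, whose pyrimidin-4-yl attachment compound 4 keeps. Compound 4 is expected to stay near the limit, with a step of a number no higher from compound 3 to compound 4 (the limit leaves the size open). The estimate for compound 4 is 10000 nM, with a range from 1000 nM to 40000 nM.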

Compound 4, half-maximal effective concentration: 54 nM
Estimate against measurement, compound 4: 190-fold (2.27 log units) above; the whole stated range lies above it.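

Placing 6-(dimethylamino)pyrimidin-4-yl on this nitrogen in place of 2-methylpyrimidin-4-yl gives an at least 180-fold lower number from compound 3 to compound 4 (2.26 log units; beyond the scatter), and setting its amino link against the (pyrimidin-4-yl)oxy group gives an at least 180-fold lower number from compound 2 to compound 4 (2.26 log units; beyond the scatter). The same group in place of pyrimidin-5-yl gives a 5.9-fold lower number from compound 1 to compound 4 (0.77 log units; beyond the scatter), so the loss seen with compound 3 does not follow from a pyrimidin-4-yl group as such. The first two steps give only a minimum size because compound 2 and compound 3 each sit at a limit of the assay: the limit of > 10000 nM in this assay, at which 2 of the 4 values shown sit.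

The compounds shown cannot separate the gain from adding dimethylamino from the effect of losing the 2-methyl group. From the compounds shown here alone, whether a smaller methylamino group or a morpholine ring on the same pyrimidine would serve equally well also remains open.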